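A few compounds are considered here, and "the series" means these few. Any claim that something is new, unique, unknown or untested is made for them only; others in the source may bear on it.

Working notes on the series. Compound 2 `O=C(c1ccn(-c2ccc3c(c2)B(O)OC3)c1)c1ccccc1Cl` in an ADME assay on L929 cells (Mus musculus) for cytotoxicity, read by resazurin assay, with a stated time of 72 h (on this read-out lower numbers stand for stronger inhibition and higher numbers for weaker inhibition), gives > 10 ug/mL; this is a limit of the assay and not a number. Compound 1 `O=C(c1ccn(-c2ccc3c(c2)B(O)OC3)c1)c1ccc(Cl)cc1Cl` in this assay gives > 10 ug/mL, again a limit. Among the compounds with values here, the only step between measured compounds, a step that the two limits leave unreadable from compound 1 to compound 2, rests on hydrogen in place of chloro on an aromatic carbon, and its size cannot be read, since (the limit of > 10 ug/mL in this assay, at which 2 of the 2 values shown sit). Compound 3 `O=C(c1ccc(F)cc1)c1ccn(-c2ccc3c(c2)B(O)OC3)c1` is not yet measured; it differs from compound 2 by 4-fluorophenyl in place of 2-chlorophenyl on a carbonyl carbon. Within the data shown here, no measured step covers an exchange at the carbonyl carbon, so the expectation for compound 3 rests only on both measured values sitting at the limit. The step from compound 2 to compound 3 is expected to be a step that the limit leaves unreadable from compound 2 to compound 3, meaning no change readable beyond the scatter. Compound 3 is therefore estimated at 15 ug/mL, between 5 ug/mL and 40 ug/mL, with the value most probably again reported as a limit.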

Compound 3, half-maximal inhibitory concentration: > 10 ug/mL
Compound 3: only a limit was reported; the forecaster's own chance of this, stated with the estimate: 75%; the middle value is on the limit's open side.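

The steps among compound 1, compound 2 and compound 3 in this assay cannot be read, because all three values are limits of the assay and not numbers: the limit of > 10 ug/mL in this assay, at which 3 of the 3 values shown sit.

The compounds shown leave open whether any exchange on the carbonyl carbon would bring the read-out off this limit.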